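The source may hold more compounds than are shown below. What is called first, only, known or untested is meant among the compounds shown, and "the series" means these compounds.

Of the compounds shown here, three built on one shared core have been tested in a functional assay on MCF7 cells (Homo sapiens) for antiproliferative activity, read by MTT assay, with a stated time of 72 h; on this read-out lower numbers stand for stronger inhibition and higher numbers for weaker inhibition. Compound 1 `COc1cc(-n2ncnc2-c2ccc(OC(C)C)cc2)cc(OC)c1OC` is the only one of them to give a number: in this assay compound 1 gives 610 nM. Compound 2 `COc1cc(-c2ncnn2-c2ccc(Cl)c(Cl)c2)cc(OC)c1OC` reaches only a limit of the assay, > 10000 nM, in this assay. Compound 3 `COc1cc(-c2ncnn2-c2ccc(Cl)cc2Cl)cc(OC)c1OC` likewise gives a limit, > 10000 nM, in this assay. Within the data shown here, the one step between measured compounds, a step that the two limits leave unreadable from compound 2 to compound 3, therefore cannot be read, since both of its ends sit at the limit of > 10000 nM in this assay, at which 2 of the 3 values shown sit.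

Compound 4 `CCOc1ccc(-c2ncnn2-c2cc(OC)c(OC)c(OC)c2)cc1` has not yet been measured. It differs from compound 1 in a single place: hydrogen in place of methyl on a saturated chain carbon bound to an oxygen on an aromatic ring and a saturated chain carbon. Among the measured compounds shown here, no measured step touches a change of this kind; the only measured step concerns the dichlorophenyl pattern, and its size is hidden by the limits. The expectation for compound 4 therefore rests on the change itself, a loss of one carbon on a chain, and on compound 1 as its nearest measured neighbour. Compound 4 is expected to give an estimated 700 nM, with a likely range from 250 nM to 2000 nM. The step this estimate means, a 1.1-fold higher number from compound 1 to compound 4 (0.06 log units; within the scatter), is expected to stay within the usual scatter, in no particular direction.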

Compound 4, half-maximal inhibitory concentration: 50 nM
Compound 4: the middle estimate sits 14-fold (1.15 log units) above what was measured; the whole stated range lies above it.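

The isopropoxy group of compound 1 is not the best fit at this position: going from isopropoxy to ethoxy, which takes one methyl off a saturated chain carbon bound to an oxygen on an aromatic ring, gives a 12-fold lower number from compound 1 to compound 4 (1.09 log units; beyond the scatter) in this assay. Among these compounds, this shows that the position responds strongly to a very small change, since the loss of a single carbon moves the number well beyond the scatter, something the earlier compounds could not show because their only step cannot be read. Nothing measured here explains why the ethoxy compound gives the lower number.

On these data alone, a single step gives a direction for this one pair and does not make a trend, so it remains open whether a methoxy group, a hydroxyl group or an amine in place of the ethoxy group would lower the number further or raise it again, and how a longer chain such as butoxy would compare. Compound 2 and compound 3 differ from compound 4 in more than one place, so they add nothing to this question.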